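Fluorophenyl switch across carboxy and carbamoyl cores

The compounds below may be only part of what the source reports. "The series", "measured", "known", "first", "only" and "open" are said of these compounds alone.

Compound 1 `CN1CCN(c2ccc(Nc3nc(-c4cccc(NC(=O)c5cccc(F)c5)c4)sc3C(=O)O)cc2)CC1` and compound 2 `CN1CCN(c2ccc(Nc3nc(-c4cccc(NC(=O)c5ccccc5F)c4)sc3C(=O)O)cc2)CC1` share a carboxy core; compound 3 `CN1CCN(c2ccc(Nc3nc(-c4cccc(NC(=O)c5cccc(F)c5)c4)sc3C(N)=O)cc2)CC1` and compound 4 `CN1CCN(c2ccc(Nc3nc(-c4cccc(NC(=O)c5ccccc5F)c4)sc3C(N)=O)cc2)CC1` share a carbamoyl core. The two cores differ as amino in place of hydroxy on a carbonyl carbon. In a functional assay on Ramos cells (Homo sapiens) for antiproliferative activity, read by CCK-8 assay, with a stated time of 72 h, tested at 40 uM (on this read-out lower numbers stand for less inhibition and higher numbers for more inhibition at the one concentration tested (going by the name of the read-out)), compound 1 gives 82.7%, compound 2 gives 93.4% and compound 3 gives 16.2%. The change from compound 1 to compound 2 is 2-fluorophenyl in place of 3-fluorophenyl on a carbonyl carbon and it made a step of a number 10.7 percentage points higher from compound 1 to compound 2 (beyond the scatter). Changing the core alone gave a number 66.5 percentage points lower from compound 1 to compound 3 (beyond the scatter), which leaves compound 3 as the lowest of the three measured numbers. Compound 4 carries the same change as compound 2, (2-fluorophenyl in place of 3-fluorophenyl on a carbonyl carbon), and the place is described in the same words for both pairs. Compound 4 is expected to show a step of a number 7.8 percentage points higher from compound 3 to compound 4 (within the scatter), because a number 10.7 percentage points higher from compound 1 to compound 2 (beyond the scatter) was modest and the carbamoyl core starts from a far lower number, so a step of comparable or somewhat smaller size is taken as the estimate. Compound 4 is therefore expected to give about 24% in this assay, estimated between 10% and 40%.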

Compound 4, a percentage reported as inhibition, at one concentration (the size of the read-out at that concentration, not a potency): 95.5%
Compound 4: the middle estimate sits 71.5 percentage points below what was measured; measured number above the stated range.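

On the carbamoyl core, 2-fluorophenyl in place of 3-fluorophenyl gave a number 79.3 percentage points higher from compound 3 to compound 4 (beyond the scatter) in this assay, and the size of this step does not match the one on the carboxy core: the same change on two cores in this assay, a number 10.7 percentage points higher (beyond the scatter) from compound 1 to compound 2 and a number 79.3 percentage points higher (beyond the scatter) from compound 3 to compound 4, 68.6 percentage points apart, beyond the scatter of two such steps With 2-fluorophenyl in place, the core change gave a number 2.1 percentage points higher from compound 2 to compound 4 (within the scatter), so the loss seen with 3-fluorophenyl does not hold for both fluorophenyl groups: the same change on two cores in this assay, a number 66.5 percentage points lower (beyond the scatter) from compound 1 to compound 3 and a number 2.1 percentage points higher (within the scatter) from compound 2 to compound 4, 68.6 percentage points apart, beyond the scatter of two such steps The size of the fluorophenyl step therefore did not carry from one core to the other here, but this rests on one pair per core at a single concentration, with compound 3 alone standing low, and it shows neither why the two cores differ nor how the steps would behave in other compounds of the series.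

Open, from the compounds shown here alone, is whether an unsubstituted phenyl or a chlorophenyl on the same carbonyl carbon would follow compound 3 or compound 4 on the carbamoyl core. Also open, going by these compounds, is how a methyl ester in place of the carboxylic acid or primary amide would behave with each fluorophenyl group.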